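The source may hold more compounds than are shown below. What is called first, only, known or untested is meant among the compounds shown, and "the series" means these compounds.

Compound 1 `COC(=O)C1=Cc2ccc(OC)cc2OC1c1cc(OC)c(OC)c(OC)c1`: in a functional assay for inhibition of nuclear factor NF-kappa-B complex (Homo sapiens) (a higher number here means a weaker inhibitor, a lower number a stronger inhibitor), compound 1 gives 13800 nM.
Compound 2 `CCCCNC(=O)C1=Cc2ccc(OC)cc2OC1c1cc(OC)c(OC)c(OC)c1`: compound 2 gives 25500 nM.
Compound 3 `COc1ccc2c(c1)OC(c1cc(OC)c(OC)c(OC)c1)C(C(=O)O)=C2`: compound 3 gives > 50000 nM, which is a limit of the assay and not a number.

The three measured compounds share one core and differ only at the carbonyl group. Compound 3 carries the free acid there, and for it only the limit is known, so it stands as the weakest inhibitor that can be placed on these numbers (the limit of > 50000 nM in this assay, at which 1 of the 3 values shown sits). Replacing the methyl ester of compound 1 with the butyl amide gave a 1.8-fold higher number from compound 1 to compound 2 (0.27 log units; within the scatter). Going from ester to acid gave an at least 3.6-fold higher number from compound 1 to compound 3 (0.55 log units; beyond the scatter), and from butyl amide to acid gave an at least 1.9-fold higher number from compound 2 to compound 3 (0.29 log units; that floor lies within the scatter).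

Compound 4 `CCNC(=O)C1=Cc2ccc(OC)cc2OC1c1cc(OC)c(OC)c(OC)c1` is the next step: ethylamino in place of hydroxy on a carbonyl carbon. This is the reverse of the step from compound 2 to compound 3, with a shorter chain on the nitrogen. The acid is the weakest member here, so converting it back into an amide is expected to move the number down, toward where compound 2 sits, giving an expected step of an at least 2.0-fold lower number from compound 3 to compound 4 (0.30 log units; that floor lies within the scatter). Compound 4 is therefore estimated at 25000 nM, with a likely range from 8000 nM to 80000 nM.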

Compound 4, half-maximal inhibitory concentration: > 50000 nM
Compound 4 gave a limit, no number; the forecaster's own chance of this, stated with the estimate: 25%; middle value at least 2.0-fold (0.30 log units) away from the limit.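

In this assay compound 4 gives > 50000 nM, a limit of the assay and not a number, so an amide on this carbonyl carbon does not by itself give a readable value. Shortening the chain on the amide nitrogen from butyl to ethyl gives an at least 1.9-fold higher number from compound 2 to compound 4 (0.29 log units; that floor lies within the scatter), so the role of chain length stays unsettled, while exchanging the methoxy of the ester for ethylamino gives an at least 3.6-fold higher number from compound 1 to compound 4 (0.55 log units; beyond the scatter), a change that can be told apart from repeat-measurement noise. The change from carboxy to ethylcarbamoyl cannot be read at all, and neither can any size be put on it, because both compounds end at the same ceiling: the limit of > 50000 nM in this assay, at which 2 of the 4 values shown sit.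

The compounds shown leave open whether a propyl chain or a chain longer than butyl on the amide nitrogen would give a measurable number in this assay. They also leave open how an ethyl ester, or an amide carrying no chain on its nitrogen, would compare with the methyl ester of the shared core.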